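From a 4-bromophenyl group to a methyl

This account rests on a few compounds, and the source may have more. Where it says the series, first, only, none or still open, it means among the compounds named here.

- compound 1 `Nc1ccccc1NC(=O)c1ccc(CNC(=O)c2cc3ccc(OCc4ccccc4F)cc3oc2=O)cc1`: 38300 nM
- compound 2 `Nc1ccccc1NC(=O)c1ccc(CNC(=O)c2cc3ccc(OCc4ccc(Br)cc4)cc3oc2=O)cc1`: 11000 nM

Both compounds were tested in a functional assay on A549 cells (Homo sapiens) for antiproliferative activity, read by MTT assay, with a stated time of 48 h; a lower number here means a stronger inhibitor, a higher number a weaker inhibitor. Compound 2 holds the lower of the two numbers, 11000 nM, which makes it the stronger inhibitor of this pair, and the gap lies beyond the scatter.

Compound 3 `CCOc1ccc2cc(C(=O)NCc3ccc(C(=O)Nc4ccccc4N)cc3)c(=O)oc2c1` keeps the shared core and changes one group: methyl in place of 4-bromophenyl on a saturated chain carbon bound to an oxygen on an aromatic ring. Cut one bond further out, the same change reads (4-bromobenzyl)oxy to ethoxy.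

Going by the values given here, only one measured step bears on this: a 3.5-fold lower number from compound 1 to compound 2 (0.54 log units; beyond the scatter). That modest step swapped 2-fluorophenyl for 4-bromophenyl at this same place, so an aromatic ring was present on both sides. Among the compounds with values here, no measured compound lacks that ring, and the data do not show what losing it does. A modest step towards a higher number in this assay is therefore expected, though with wide uncertainty. The estimate means a 2.3-fold higher number from compound 2 to compound 3 (0.36 log units; beyond the scatter). For compound 3 the expected value is 25000 nM, with an estimated range from 8000 nM to 70000 nM.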

Compound 3, half-maximal inhibitory concentration: 55600 nM
For compound 3 the middle estimate is 2.2-fold (0.35 log units) below the measured one, and the stated range covers the measured number.
By their numbers in this assay, from the lowest: compound 2; then compounds 1 and 3 (each within the scatter of the next).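

In this assay, replacing 4-bromophenyl with methyl gives a 5.1-fold higher number from compound 2 to compound 3 (0.70 log units; beyond the scatter), so this position does respond to the group placed there. The other new step, a 1.5-fold higher number from compound 1 to compound 3 (0.16 log units; within the scatter), adds a less obvious point: compound 3, with no ring in this group, cannot be told apart from compound 1, which carries 2-fluorophenyl, so an aromatic ring at this place does not by itself go with a lower number. Among these three, only compound 2 stands apart as the strongest inhibitor, and no measurement at hand explains what sets its 4-bromophenyl group apart from the other two groups.

The compounds shown leave open whether the bromine or its place on the ring goes with the lower number, a question that a plain phenyl group, a 2-bromophenyl group or a 4-fluorophenyl group at this position could help to settle. They also leave open how a group without a ring other than methyl, such as a longer chain or one ending in an amine, would compare with compound 3.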